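A few compounds are considered here, and "the series" means these few. Any claim that something is new, unique, unknown or untested is made for them only; others in the source may bear on it.

Compound 1 `S=C(Nc1ccccc1)N1N=C(c2ccc(Cl)cc2)CC1c1ccc2c(c1)OCCO2`: 187000 nM
Compound 2 `FC(F)(F)c1ccc(C2=NN(C(=S)Nc3ccccc3)C(c3ccc4c(c3)OCCO4)C2)cc1`: 97500 nM
Compound 3 `O=[N+]([O-])c1ccc(C2=NN(C(=S)Nc3ccccc3)C(c3ccc4c(c3)OCCO4)C2)cc1`: 153000 nM

In a functional assay on HT-29 cells (Homo sapiens) for antiproliferative activity, read by MTT assay, with a stated time of 48 h (a lower number here means a stronger inhibitor of growth, a higher number a weaker inhibitor of growth), compound 1 gives the highest of the three numbers; compound 3 lies nearest to it and compound 2 furthest, yet both steps, a 1.2-fold lower number from compound 1 to compound 3 (0.09 log units; within the scatter) and a 1.9-fold lower number from compound 1 to compound 2 (0.28 log units; within the scatter), stay within the scatter. Compound 4 `S=C(Nc1ccccc1)N1N=C(c2ccccc2Br)CC1c1ccc2c(c1)OCCO2` is not yet measured. It differs from compound 1 in one place: 2-bromophenyl in place of 4-chlorophenyl on a carbon with a double bond to nitrogen. Within the data shown here, no measured step exchanges one halogen-bearing phenyl for another of this kind; the steps that come closest alter the group on that same phenyl ring, and neither of them, nor a 1.6-fold higher number from compound 2 to compound 3 (0.20 log units; within the scatter), moves beyond the scatter. On that record no step beyond the scatter is expected for compound 4, and a 1.1-fold lower number from compound 1 to compound 4 (0.04 log units; within the scatter) is the expected step. Compound 4 is therefore estimated at 170000 nM, between 60000 nM and 450000 nM.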

Compound 4, concentration for 50% growth inhibition: > 200000 nM
Compound 4 gave a limit, no number; the forecaster's own chance of this, stated with the estimate: 10%; middle value at least 1.1-fold (0.07 log units) from the limit.
By their numbers in this assay, from the lowest: compounds 2, 3 and 1 (each within the scatter of the next). At a limit, above all of these: compound 4.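

Among these compounds, compound 4 gives only a limit in this assay, not a number: the limit of > 200000 nM in this assay, at which 1 of the 4 values shown sits. With 2-bromophenyl on this carbon, an at least 2.0-fold higher number from compound 2 to compound 4 (0.31 log units; beyond the scatter) is the first step at this position to pass beyond the scatter. The floors of an at least 1.0-fold higher number from compound 1 to compound 4 (0.02 log units; that floor lies within the scatter) and an at least 1.3-fold higher number from compound 3 to compound 4 (0.11 log units; that floor lies within the scatter) stay within the scatter, so neither pair can be ordered.

From the compounds shown here alone, what 4-bromophenyl or 2-chlorophenyl would give on this carbon stays open, so the halogen and its place on the ring cannot be told apart. Going by these compounds, an amine or a carboxylic acid on that phenyl also remains open.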